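This account rests on a few compounds, and the source may have more. Where it says the series, first, only, none or still open, it means among the compounds named here.

Measured compounds:
- compound 1, `COc1cc(/C=C/C(=O)c2sc(Nc3ccc(Cl)cc3)nc2C)cc(OC)c1OC`: > 25000 nM
- compound 2, `COc1cccc(/C=C/C(=O)c2sc(Nc3ccccc3)nc2C)c1`: 14300 nM

Notes on the series. In a functional assay on BGC-823 cells (Homo sapiens) for cytotoxicity, read by MTT assay (on this read-out higher numbers stand for weaker inhibition and lower numbers for stronger inhibition), compound 1 reaches only the limit of the assay, > 25000 nM, and no number is known for it. Compound 2 gives 14300 nM in this assay. The two differ in more than one place, so the gap between them is not read as a single step; compound 1 sits at the limit, as shown by the limit of > 25000 nM in this assay, at which 1 of the 2 values shown sits.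

Compound 3, `COc1cc(/C=C/C(=O)c2sc(Nc3ccc(C)cc3)nc2C)cc(OC)c1OC`, is not yet measured. Relative to compound 1 the change is methyl in place of chloro on an aromatic carbon, in words: methyl in place of chloro on an aromatic carbon. Among the compounds with values here, no measured step of this kind exists, so the expected step from compound 1 to compound 3 in this assay is a step that the limit leaves unreadable from compound 1 to compound 3, taken as none beyond the scatter, with the limit of compound 1 as the only anchor. Compound 3 is therefore expected to give about 30000 nM in this assay, estimated between 10000 nM and 80000 nM.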

Compound 3, half-maximal inhibitory concentration: > 25000 nM
Compound 3: only a limit was reported (the forecaster's own chance of this, stated with the estimate: 60%); the middle value does not contradict the limit.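

Within the data shown here, no step from compound 1 to compound 3 can be read in this assay, as the values of both compounds are limits and not numbers: the limit of > 25000 nM in this assay, at which 2 of the 3 values shown sit.

The compounds shown leave open how far methyl in place of chloro on an aromatic carbon shifts the value in this assay.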